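A few compounds are considered here, and "the series" means these few. Any claim that something is new, unique, unknown or untested is made for them only; others in the source may bear on it.

Compound 3 `Nc1ccccc1NC(=O)c1ccc(CSC(=S)N2CCN(c3ccncc3)CC2)cc1` is measured in a functional assay on HeLa cells (Homo sapiens) for antiproliferative activity, read by CCK-8 assay, with a stated time of 72 h, tested at 8 uM (on this read-out lower numbers stand for a weaker effect and higher numbers for a stronger effect at the one concentration tested), where compound 3 gives 77.4%. Compound 2 `Nc1ccccc1NC(=O)c1ccc(CSC(=S)N2CCN(C3CCCCC3)CC2)cc1` gives 76.1%, a gap within the scatter, while compound 1 `Nc1ccccc1NC(=O)c1ccc(CSC(=S)N2CCN(Cc3ccccn3)CC2)cc1` gives 61.4%, well below both. Compound 4 `Nc1ccccc1NC(=O)c1ccc(CSC(=S)N2CCN(c3ccccc3F)CC2)cc1` differs from compound 3 by 2-fluorophenyl in place of pyridin-4-yl on an amine nitrogen in a ring. Going by the values given here, two measured steps touch the same ring nitrogen: a number 1.3 percentage points higher from compound 2 to compound 3 (within the scatter), within the scatter, and a number 16 percentage points higher from compound 1 to compound 3 (beyond the scatter), beyond it. Putting pyridin-4-yl in place of cyclohexyl on that nitrogen moved the number only within the scatter, so another swap of the group there is expected to give about a number 2.4 percentage points lower from compound 3 to compound 4 (within the scatter), nothing beyond the scatter. Compound 4 is therefore estimated at 75%, between 62% and 86%.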

Compound 4, a percentage reported as inhibition, at one concentration (the size of the read-out at that concentration, not a potency): 59.2%
Compound 4: the middle estimate sits 15.8 percentage points above what was measured; the whole stated range lies above it.
By their numbers in this assay, from the lowest: compounds 4 and 1 (each within the scatter of the next); then compounds 2 and 3 (each within the scatter of the next).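

The group on this ring nitrogen clearly matters: the earlier tie between cyclohexyl and pyridin-4-yl does not extend to 2-fluorophenyl (a number 18.2 percentage points lower from compound 3 to compound 4 (beyond the scatter); a number 16.9 percentage points lower from compound 2 to compound 4 (beyond the scatter)). A six-membered aromatic ring on this nitrogen is not enough for the higher number, since compound 3 and compound 4 both carry one, and the result instead falls level with the (pyridin-2-yl)methyl compound (a number 2.2 percentage points lower from compound 1 to compound 4 (within the scatter)). Nothing measured here explains the drop.

Still open, from the compounds shown here alone, is whether the fluorine or the missing ring nitrogen goes with the lower number; an unsubstituted phenyl on the same nitrogen would separate the two.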